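A Phenyl Added to the Core of Compound 2

A few compounds are considered here, and "the series" means these few. Any claim that something is new, unique, unknown or untested is made for them only; others in the source may bear on it.

Compound 2 `O=S(=O)(Nc1cc(-c2cnc3[nH]ncc3c2)cnc1Cl)c1ccccc1` was tested in a functional assay on U-87MG ATCC cells for inhibition, with U-87 MG (Homo sapiens) as the target, read by sulforhodamine B assay, with a stated time of 72 h (a higher number here means a weaker inhibitor of growth, a lower number a stronger inhibitor of growth), where compound 2 gives 8940 nM. Within the data shown here, the only other measured analogue, compound 1 `O=S(=O)(Nc1cc(-c2cnc3[nH]cc(-c4ccncc4)c3c2)cnc1Cl)c1ccccc1F`, gives 7130 nM in this assay, a number that lies within the scatter of compound 2's, so neither stands apart. Compound 3 `O=S(=O)(Nc1cc(-c2cnc3[nH]nc(-c4ccccc4)c3c2)cnc1Cl)c1ccccc1` carries phenyl in place of hydrogen on an aromatic carbon. Among the measured compounds shown here, no measured pair shows this change, so the step of a 2.2-fold lower number from compound 2 to compound 3 (0.35 log units; beyond the scatter) is expected to be modest, toward stronger growth inhibition. Compound 3 is therefore estimated at 4000 nM, with a range from 1000 nM to 15000 nM.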

Compound 3, concentration for 50% growth inhibition: > 10000 nM
Compound 3 ended at the assay's limit; the forecaster's own chance of this, stated with the estimate: 10%; middle value at least 2.5-fold (0.39 log units) away from the limit.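

In this assay compound 3 gives a limit, not a number: the limit of > 10000 nM in this assay, at which 1 of the 3 values shown sits. The step, an at least 1.1-fold higher number from compound 2 to compound 3 (0.04 log units; that floor lies within the scatter), shows that phenyl in place of hydrogen on this aromatic carbon of the five-membered ring brought no stronger growth inhibition, the direction that had been expected. How much weaker compound 3 may be cannot be read from this floor.

The compounds shown leave open whether a smaller group on this carbon, such as methyl, would be tolerated. They also leave open how an amine or a carboxylic acid there would compare.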